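The source may hold more compounds than are shown below. What is called first, only, known or untested is meant among the compounds shown, and "the series" means these compounds.

Measured so far:
compound 1, `CC(C)(C)[C@H](N)CN(C(=O)[C@@H]1C[C@H]1c1ccccc1)c1ccc(-c2ccccc2)cc1`, 11 nM
compound 2, `CC[C@H](C)[C@H](N)CN(C(=O)[C@@H]1C[C@H]1c1ncc(C)s1)c1ccc(-c2ccccc2)cc1`, 1300 nM
compound 3, `CCc1ccc(-c2ccc(N(C[C@@H](N)[C@@H](C)CC)C(=O)[C@@H]3C[C@H]3c3ccccc3)cc2)cc1`, 44 nM

In a functional assay for agonist activity at G protein-coupled receptor 88 (Homo sapiens), read by HTRF and cAMP accumulation (a higher number here means that more compound is needed for the effect, a lower number that less compound is needed), compound 3 stands second highest of the three numbers. Its nearest neighbour is compound 1, whose number is lower by a gap that lies beyond the scatter; furthest away is compound 2, whose number is higher, again beyond the scatter. Compound 3 therefore sits between the two, closer to compound 1.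

Compound 4, `CC[C@H](C)[C@H](N)CN(C(=O)[C@@H]1C[C@H]1c1ccccc1)c1ccc(-c2ccc(N)cc2)cc1`, has not been measured in this assay. It differs from compound 3 in one place: amino in place of ethyl on an aromatic carbon. Among the measured compounds shown here, since no pair of measured compounds that differ by only this change is available, nothing in the numbers at hand shows how this exchange acts on its own. The three measured compounds differ from one another in several places at once, so they give only a rough frame.

The step from compound 3 to compound 4 is expected to be small, a 1.4-fold higher number from compound 3 to compound 4 (0.13 log units; within the scatter), most likely within the scatter of the assay, with a slight lean towards a higher number. On that basis compound 4 is estimated at 60 nM in this assay, with a plausible range from 15 nM to 250 nM.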

Compound 4, half-maximal effective concentration: 320 nM
Compound 4: middle estimate off by 5.3-fold (0.73 log units), on the low side, and the stated range ends below it.
By their numbers in this assay, from the lowest: compound 1; then compound 3; then compound 4; then compound 2.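

In this assay, the exchange of 4-ethylphenyl for 4-aminophenyl gives a 7.3-fold higher number from compound 3 to compound 4 (0.86 log units; beyond the scatter), the only step shown so far in which a single place changes. It shows that the substituent on this six-membered aromatic ring of carbon only, para to a large group, can move the number beyond the scatter, and that amino in place of ethyl moves it upward here. Ethyl, with two carbons and no hydrogen-bond donor or acceptor, leaves, while amino, with one nitrogen, one donor and one acceptor, enters, and no measurement at hand accounts for the step.

On these data alone, whether the higher number follows from the arrival of amino or from the loss of ethyl remains open, and a methyl, a methoxy, a hydroxyl, a longer chain such as propyl or a plain hydrogen at this position could help to separate the two. As far as these compounds go, it also remains open whether the same exchange would give a step of similar size and direction on the core of compound 1 or of compound 2.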